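Cyanoguanidine chain variation on a pyridazinone series: gastric read-out

This account rests on a few compounds, and the source may have more. Where it says the series, first, only, none or still open, it means among the compounds named here.

Of the compounds shown here, two have numbers so far. Compound 1 `CN(C)/C(=N/CCCCn1nc(-c2ccccc2)ccc1=O)NC#N` and compound 2 `NC(=O)SCCCCCN1NC=CC=C1c1ccccc1` were run in a functional assay on the whole organism (stomach) with Rattus norvegicus as the target; on this read-out lower numbers stand for an effect already at smaller amounts and higher numbers for an effect only at larger amounts of compound. In this assay compound 1 gives 30.3 mg/kg, and compound 2 gives 23.8 mg/kg. Compound 1 holds the higher of the two numbers, yet the gap lies within the scatter of repeated measurements, so the two compounds cannot be told apart on this read-out.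

Compound 3 `C/N=C(\NC#N)NCCCCn1nc(-c2ccccc2)ccc1=O` has not yet been measured. It differs from compound 1 in one place: a group of 7 heavy atoms (3 carbon, 4 nitrogen; no ring) in place of a group of 8 heavy atoms (4 carbon, 4 nitrogen; no ring), on a saturated chain carbon, four bonds along the chain from an aromatic nitrogen. The core of compound 1 and the chain leading to it are kept, with only the terminal group changed.

For the measured compounds named here, no pair of measured compounds differs in this way, so there is no measured step to lean on. With nothing in the data pointing either way, the step from compound 1 to compound 3 is expected to stay within the scatter, giving a 1.0-fold lower number from compound 1 to compound 3 (0.00 log units; within the scatter). Compound 3 is therefore estimated at 30 mg/kg in this assay, with a range from 12 mg/kg to 75 mg/kg.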

Compound 3, dose for half-maximal effect: 32.4 mg/kg
The estimate for compound 3 lay 1.1-fold (0.03 log units) below the measured number, within the range that was stated.
By their numbers in this assay, from the lowest: compounds 2, 1 and 3 (each within the scatter of the next).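

At this position, on a saturated chain carbon, four bonds along the chain from an aromatic nitrogen, the terminal group can be exchanged in this assay with a step of a 1.1-fold higher number from compound 1 to compound 3 (0.03 log units; within the scatter), which is within the scatter. The entering group has 7 heavy atoms and 2 hydrogen-bond donors, the leaving group 8 heavy atoms and 1 hydrogen-bond donor. For the compounds shown here, this single exchange gives the first one-place comparison. Compound 2 differs from compound 1 in more than one place and does not provide such a comparison. Nothing on hand offers an explanation for the size of this step.

Still open, going by these compounds, is whether the chain end tolerates a group of a different kind, such as a primary amine or a carboxylic acid, as it tolerates this exchange. Also open, on these data alone, is whether a longer chain to the shared core, with the terminal group of compound 3 kept, would produce a step beyond the scatter on this read-out.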